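Chloro Substitution on a Core Already at the Toxicity Limit

The compounds below may be only part of what the source reports. "The series", "measured", "known", "first", "only" and "open" are said of these compounds alone.

Three compounds have been measured in an ADME assay on MT4 cells (Homo sapiens) for cytotoxicity; on this read-out lower numbers stand for higher toxicity in this test and higher numbers for lower toxicity in this test:
Compound 1 `Cc1cc(C)cc(S(=O)(=O)n2c(SCC(=O)Nc3ccc(C)cc3Cl)nc3ccccc32)c1` gives 5400 nM.
Compound 2 `Cc1cc(C)cc(S(=O)(=O)n2c(SCC(=O)Nc3ccc(C)cc3Cl)nc3ccc(Cl)cc32)c1` is returned only as a limit of the assay, > 234000 nM.
Compound 3 `Cc1cc(C)cc(S(=O)(=O)n2c(SCC(=O)Nc3ccc(S(C)(=O)=O)cc3Cl)nc3ccccc32)c1` is likewise returned only as a limit of the assay, > 221000 nM.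

Compound 1 and compound 2 differ in one place: chloro in place of hydrogen on an aromatic carbon. In this assay this change gave an at least 43-fold higher number from compound 1 to compound 2 (1.63 log units; beyond the scatter), a step that can only be bounded because compound 2 sits at the limit of > 234000 nM in this assay, at which 1 of the 3 values shown sits.

Compound 3 differs from compound 1 in the other part of the molecule: methylsulfonyl in place of methyl on an aromatic carbon. This change gave an at least 40-fold higher number from compound 1 to compound 3 (1.61 log units; beyond the scatter), again only bounded because compound 3 sits at the limit of > 221000 nM in this assay, at which 1 of the 3 values shown sits.

Compound 4 `Cc1cc(C)cc(S(=O)(=O)n2c(SCC(=O)Nc3ccc(S(C)(=O)=O)cc3Cl)nc3ccc(Cl)cc32)c1` has not yet been measured. It stands to compound 3 as compound 2 stands to compound 1: chloro in place of hydrogen on an aromatic carbon, the same change at the same place, here made on the core of compound 3.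

In this assay the step to compound 4 is expected to be a step that the limit leaves unreadable from compound 3 to compound 4. This expectation rests on compound 3 already sitting at the limit of > 221000 nM in this assay, at which 1 of the 3 values shown sits, and on the same change having produced an at least 43-fold higher number from compound 1 to compound 2 (1.63 log units; beyond the scatter). Compound 4 is therefore estimated to give about 350000 nM in this assay, most likely between 180000 nM and 1500000 nM, and the result is expected to come back as a limit rather than a number.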

Compound 4, half-maximal cytotoxic concentration: 3590 nM
Beside the measured number, compound 4's estimate is 97-fold (1.99 log units) above it, outside the stated range (below it).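

In this assay, chloro in place of hydrogen on an aromatic carbon did not carry from one core to the other: on the core of compound 3 it gave an at least 61-fold lower number from compound 3 to compound 4 (1.78 log units; beyond the scatter), against the rise seen on the core of compound 1: the same change on two cores in this assay, an at least 43-fold higher number (1.63 log units; beyond the scatter) from compound 1 to compound 2 and an at least 61-fold lower number (1.78 log units; beyond the scatter) from compound 3 to compound 4, at least 2600-fold (3.42 log units) apart, beyond the scatter of two such steps. Methylsulfonyl in place of methyl on an aromatic carbon reversed in the same way, giving an at least 65-fold lower number from compound 2 to compound 4 (1.81 log units; beyond the scatter) on the chlorinated core: the same change on two cores in this assay, an at least 40-fold higher number (1.61 log units; beyond the scatter) from compound 1 to compound 3 and an at least 65-fold lower number (1.81 log units; beyond the scatter) from compound 2 to compound 4, at least 2600-fold (3.42 log units) apart, beyond the scatter of two such steps. Within the data shown here, compound 2 and compound 3 are returned only as limits of the assay, which leaves every step here a bound, and these four compounds show only that the two changes do not act independently of each other; they give no reason for the reversal and say nothing about any further core.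

The compounds shown leave open whether a fluoro or bromo group at the same place on the core would follow chloro in this reversal. They also leave open whether a carboxylic acid or an amine in place of the methylsulfonyl would show the same dependence on the core.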